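Swapping Cyclohexyl for a Hydroxyalkyl Chain on a Shared Core

The compounds below may be only part of what the source reports. "The series", "measured", "known", "first", "only" and "open" are said of these compounds alone.

Measured compounds:
compound 1, `Nc1ncnc2c1c(-c1cc(C3CC3)on1)nn2C1CCCCC1`, > 10000 nM
compound 2, `CC(C)n1nc(/C=N/OCc2ccccc2)c2c(N)ncnc21`, > 10000 nM
compound 3, `CC(C)n1nc(-c2cc(-c3ccc(F)cc3)on2)c2c(N)ncnc21`, > 10000 nM

The study records three compounds in an ADME assay on BaF3 cells (Mus musculus) for cytotoxicity, read by MTT assay, with a stated time of 48 h; a lower number here means a stronger inhibitor of growth, a higher number a weaker inhibitor of growth. Compound 1 reaches only a limit of the assay, > 10000 nM. Compound 2 likewise reaches only a limit, > 10000 nM. Compound 3 also sits at a limit, > 10000 nM. So none of the three gives a number, and compound 1 cannot be placed against the others beyond the fact that all three share the same limit: the limit of > 10000 nM in this assay, at which 3 of the 3 values shown sit.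

Compound 4, `CC(C)(O)Cn1nc(-c2cc(C3CC3)on2)c2c(N)ncnc21`, has not yet been measured in this assay. It differs from compound 1 in one place: 2-hydroxy-2-methylpropyl in place of cyclohexyl on an aromatic nitrogen. Going by the values given here, no pair of measured compounds differs in a single place, so there is no measured step to lean on, and all three measured values share the limit.

Given that compound 1 shows > 10000 nM, the author expects compound 4 to behave similarly in this assay, with a step from a step that the limit leaves unreadable from compound 1 to compound 4 of no size beyond the scatter. The author's estimate for compound 4 is 20000 nM, within a range of 8000 nM to 60000 nM, most probably reported again as a limit.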

Compound 4, concentration for 50% growth inhibition: > 10000 nM
Compound 4: no number, only a limit; the forecaster's own chance of this, stated with the estimate: 80%; the middle value is on the limit's open side.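

In this assay compound 4 gives > 10000 nM as a limit, not a number. No step from compound 1 to compound 4 can be read, since both compounds stand at a limit: the limit of > 10000 nM in this assay, at which 4 of the 4 values shown sit.

The compounds shown leave open how strongly any of them inhibits growth, and whether either group on the aromatic nitrogen makes a difference.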